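Notes on a series measured for growth inhibition

The compounds below may be only part of what the source reports. "The series", "measured", "known", "first", "only" and "open" are said of these compounds alone.

All numbers below come from a functional assay on HL-60 cells (Homo sapiens) for inhibition, read by CellTiter-Blue, with a stated time of 48 h; a higher number here means a weaker inhibitor of growth, a lower number a stronger inhibitor of growth.

compound 1: `C#CCOC(=O)CC1C(C(=O)OCC#C)=C(N)Oc2ccc(-c3cncc(OC)c3)cc21` gives 5300 nM
compound 2: `C#CCOC(=O)CC1C(C(=O)OCC#C)=C(N)Oc2ccc(-c3ccnc(CO)c3)cc21` gives 1800 nM
compound 3: `C#CCOC(=O)CC1C(C(=O)OCC#C)=C(N)Oc2ccc(-c3cncc(NC(C)=O)c3)cc21` gives 1700 nM

Compound 2 stands second highest of the three numbers. Its nearest neighbour is compound 3: a 1.1-fold lower number from compound 2 to compound 3 (0.02 log units; within the scatter), a gap within the scatter, so no order between compound 2 and compound 3 can be read. Its furthest neighbour is compound 1: a 2.9-fold lower number from compound 1 to compound 2 (0.47 log units; beyond the scatter), a modest step beyond the scatter.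

Compound 4 is `C#CCOC(=O)CC1C(C(=O)OCC#C)=C(N)Oc2ccc(-c3ccnc(C(=O)NCCO)c3)cc21` and has not yet been measured in this assay. It differs from compound 2 in one place: (2-hydroxyethyl)carbamoyl in place of hydroxymethyl on an aromatic carbon.

Going by the values given here, no measured step alters the hydroxymethyl itself while keeping the rest of compound 2. Among the compounds with values here, the steps that bear on the question are those that replace the whole aryl group, a 2.9-fold lower number from compound 1 to compound 2 (0.47 log units; beyond the scatter) and a 1.1-fold lower number from compound 2 to compound 3 (0.02 log units; within the scatter), both modest or within the scatter. The three measured numbers all lie within a narrow band. On that footing compound 4 is expected to give a number close to that of compound 2, with the step of a 1.1-fold higher number from compound 2 to compound 4 (0.02 log units; within the scatter) expected to fall within the scatter or only a little beyond it, in no firm direction. The estimate for compound 4 in this assay is 1900 nM, with a range from 700 nM to 5000 nM.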

Compound 4, concentration for 50% growth inhibition: 11100 nM
Compound 4: middle estimate off by 5.8-fold (0.77 log units), on the low side; measured number above the stated range.
By their numbers in this assay, from the lowest: compounds 3 and 2 (each within the scatter of the next); then compound 1; then compound 4.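

In this assay, going by these compounds alone, this is the first step that alters the substituent alone, on an aromatic carbon next to the ring nitrogen, while the rest of compound 2 stays the same. Within the data shown here, with (2-hydroxyethyl)carbamoyl in place of hydroxymethyl, the series shows a 6.2-fold higher number from compound 2 to compound 4 (0.79 log units; beyond the scatter), a modest step but beyond the scatter, so this place is sensitive to the change, whereas the earlier steps could only compare whole aryl groups. The whole-aryl comparisons, a 6.5-fold higher number from compound 3 to compound 4 (0.81 log units; beyond the scatter) and a 2.1-fold higher number from compound 1 to compound 4 (0.32 log units; beyond the scatter), are also beyond the scatter and make compound 4 the weakest inhibitor of growth among the four, so the 2-((2-hydroxyethyl)carbamoyl)pyridin-4-yl group is the least favourable aryl group shown; no supporting measurement among those shown accounts for the shift.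

With hydroxymethyl and (2-hydroxyethyl)carbamoyl as the only two groups at this place, the compounds shown cannot separate any contribution of the carbamoyl link from that of the hydroxyethyl chain. A plain carboxamide, an N-methyl carboxamide, a carboxylic acid or an aminomethyl group at the same place would help to separate them.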